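Sulfonohydrazide series: swapping the aryl on sulfonyl sulfur

The source may hold more compounds than are shown below. What is called first, only, known or untested is meant among the compounds shown, and "the series" means these compounds.

Measured so far:
compound 1 `CC(=O)Nc1ccc(S(=O)(=O)NNC(=O)c2cccnc2Nc2ccc(Cl)cc2)cc1` — > 100000 nM
compound 2 `O=C(NNS(=O)(=O)c1ccc(F)cc1)c1cccnc1Nc1ccc(Cl)cc1Cl` — 100000 nM

In a functional assay on BT-549 cells (Homo sapiens) for antiproliferative activity (on this read-out higher numbers stand for weaker inhibition of growth and lower numbers for stronger inhibition of growth), compound 1 reaches only a limit, > 100000 nM, not a number. Compound 2 gives 100000 nM in this assay. Within the data shown here, compound 1 thus sits at the limit of > 100000 nM in this assay, at which 1 of the 2 values shown sits, and no step between measured compounds is available. Compound 3 `O=C(NNS(=O)(=O)c1ccc(Cl)cc1Cl)c1cccnc1Nc1ccc(Cl)cc1` carries 2,4-dichlorophenyl in place of 4-acetamidophenyl on a sulfonyl sulfur. Among the measured compounds shown here, no measured step guides the size of this change; anything from no change to a modest shift beyond the scatter is plausible. Compound 3 is expected to give 60000 nM in this assay, in the range 20000 nM to 100000 nM, meaning an estimated step of an at least 1.6-fold lower number from compound 1 to compound 3 (0.22 log units; that floor lies within the scatter).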

Compound 3, concentration for total growth inhibition: 34700 nM
Estimate against measurement, compound 3: 1.7-fold (0.24 log units) above; the range from low to high includes it.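

In this assay, the aryl on a sulfonyl sulfur now has a measured effect: 2,4-dichlorophenyl in place of 4-acetamidophenyl gives an at least 2.8-fold lower number from compound 1 to compound 3 (0.45 log units; beyond the scatter). Among these compounds, this is the first step that can be read. For compound 1, > 100000 nM is a limit and not a number, so the step has a floor but no upper bound: the limit of > 100000 nM in this assay, at which 1 of the 3 values shown sits.

Going by these compounds, it remains open whether one chlorine on the phenyl would give the same step as two. On these data alone, the outcome with an amine in place of the acetamide is also open.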